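The source may hold more compounds than are shown below. What is called first, only, known or untested is meant among the compounds shown, and "the series" means these compounds.

Compound 1 `CCN(Cc1c(C(F)(F)F)nc2n(-c3c(C)cc(C)cc3C)c(Cl)cn12)CC1CC1`: 9 nM
Compound 2 `C=CCN(CC=C)Cc1c(C(F)(F)F)nc2n(-c3c(C)cc(C)cc3C)c(Cl)cn12`: 13 nM
Compound 3 `CCCCN(Cc1ccccc1)Cc1c(C(F)(F)F)nc2n(-c3c(C)cc(C)cc3C)c(Cl)cn12`: 130 nM

All three were tested in an assay on cells for displacement of a labelled ligand from corticotropin-releasing factor receptor 1 (Homo sapiens), with a stated time of 100 min; a higher number here means a weaker inhibitor, a lower number a stronger inhibitor. Compound 3 gives the highest number of the three, a weaker inhibitor than compound 1 and compound 2 by steps that lie beyond the usual scatter. Compound 4 `CCCN(Cc1ccccc1)Cc1c(C(F)(F)F)nc2n(-c3c(C)cc(C)cc3C)c(Cl)cn12` differs from compound 3 by hydrogen in place of methyl on a saturated chain carbon, three bonds along the chain from an amine nitrogen. Going by the values given here, no measured pair shows this kind of shortening of a chain on the amine nitrogen. Among the compounds with values here, the only measured step at that nitrogen, a 1.4-fold higher number from compound 1 to compound 2 (0.16 log units; within the scatter), swaps both amine substituents at once and stays within the scatter. The change is therefore expected to move the number little, in no clear direction, an expected step of no change at the digits printed from compound 3 to compound 4 (within the scatter). Compound 4 is estimated at 130 nM, with a range from 50 nM to 350 nM.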

Compound 4, inhibition constant: 170 nM
Estimate against measurement, compound 4: 1.3-fold (0.12 log units) below, and the stated range covers the measured number.
By their numbers in this assay, from the lowest: compounds 1 and 2 (each within the scatter of the next); then compounds 3 and 4 (each within the scatter of the next).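

Shortening butyl to propyl on the amine nitrogen gives, in this assay, a 1.3-fold higher number from compound 3 to compound 4 (0.12 log units; within the scatter) and is the first measured change of chain length at this position. With benzyl(propyl)amino in place, the steps from the other two amines remain large, with a 13-fold higher number from compound 2 to compound 4 (1.12 log units; beyond the scatter) and with a 19-fold higher number from compound 1 to compound 4 (1.28 log units; beyond the scatter) as well. No measurement shown here offers a reason for these results.

As far as these compounds go, whether an ethyl or pentyl chain on that nitrogen would keep the number level remains open. So does the part played by the benzyl group alone, since compound 4 differs from compound 1 and compound 2 in both amine substituents.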